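Moving a Chlorine Around the Urea of a Kinase-like Scaffold

The source may hold more compounds than are shown below. What is called first, only, known or untested is meant among the compounds shown, and "the series" means these compounds.

Of the compounds shown here, three have so far been tested in a functional assay on MDA-MB-231 cells (Homo sapiens) for cytotoxicity, read by MTT assay, with a stated time of 72 h; on this read-out higher numbers stand for weaker inhibition and lower numbers for stronger inhibition. Compound 1, `CN(C)CCNc1nc(-c2ccc(NC(=O)Nc3ccc(Cl)cc3)cc2)nc2ccsc12`, carries a 4-chlorophenyl group on its urea; in this assay compound 1 gives 310 nM. Compound 2, `CN(C)CCNc1nc(-c2ccc(NC(=O)Nc3ccccc3Cl)cc2)nc2ccsc12`, differs from compound 1 only by 2-chlorophenyl in place of 4-chlorophenyl on an amide-type nitrogen. In this assay compound 2 gives 550 nM, so the change made a 1.8-fold higher number from compound 1 to compound 2 (0.25 log units; within the scatter). Compound 3, `CCN(CC)CCCNc1nc(-c2ccc(NC(=O)Nc3ccc(Cl)cc3)cc2)nc2c(Cl)c(Cl)sc12`, keeps the 4-chlorophenyl urea of compound 1 but sits on a different core; the difference between the two cores is not broken down here. In this assay compound 3 gives 660 nM, a number within the scatter of compound 2 and beyond the scatter of compound 1.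

Compound 4, `CCN(CC)CCCNc1nc(-c2ccc(NC(=O)Nc3ccccc3Cl)cc2)nc2c(Cl)c(Cl)sc12`, has not yet been measured. It differs from compound 3 by 2-chlorophenyl in place of 4-chlorophenyl on an amide-type nitrogen, the same change that was made from compound 1 to compound 2, and at the same place, since in both cases the nitrogen that carries the group has a carbonyl carbon as its other neighbour. This change appears in two pairs of compounds here, and only one of them has been measured.

Because a 1.8-fold higher number from compound 1 to compound 2 (0.25 log units; within the scatter) lay within the scatter, the step from compound 3 to compound 4 is expected to be similar, about a 1.5-fold higher number from compound 3 to compound 4 (0.18 log units; within the scatter). Compound 4 is therefore estimated at 1000 nM, with a likely range from 400 nM to 2500 nM.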

Compound 4, half-maximal inhibitory concentration: 970 nM
The estimate for compound 4 lay 1.0-fold (0.01 log units) above the measured number, within the range that was stated.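

On the core of compound 3, putting 2-chlorophenyl in place of 4-chlorophenyl on the urea gives, in this assay, a 1.5-fold higher number from compound 3 to compound 4 (0.17 log units; within the scatter). Set beside the earlier step, the change carries from one core to the other with no difference that can be told apart from ordinary measurement noise: the same change on two cores in this assay, a 1.8-fold higher number (0.25 log units; within the scatter) from compound 1 to compound 2 and a 1.5-fold higher number (0.17 log units; within the scatter) from compound 3 to compound 4, 1.2-fold (0.08 log units) apart, within the scatter of two such steps This shows that two matched pairs agree, but it does not show that moving the chlorine truly matters, since each step on its own lies within the scatter, and two pairs cannot establish a rule for any further core.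

The compounds shown leave open what happens when the chlorine itself is replaced, for example by a fluorine or a methoxy group on the same phenyl ring, or when the ring carries no substituent at all. They also leave open whether the agreement between the two cores would survive a larger change at the other end of the molecule, such as a morpholine or a carboxylic acid in place of the basic amine at the end of the side chain.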